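The compounds below may be only part of what the source reports. "The series", "measured", "known", "first", "only" and "open" are said of these compounds alone.

Of the compounds shown here, three built on one shared core have been tested in a functional assay on HCT-116 cells (Homo sapiens) for cytotoxicity, read by WST assay, with a stated time of 72 h; on this read-out higher numbers stand for weaker inhibition and lower numbers for stronger inhibition. Compound 1 `COc1cc2c(Nc3nc4ccc(C(=O)Nc5c(C)cccc5C)cc4s3)ncnc2cc1OCCCN1CCCC1` carries a pyrrolidin-1-yl group on its side chain; in this assay compound 1 gives > 100000 nM, which is a limit of the assay rather than a number. Compound 2 `COc1cc2c(Nc3nc4ccc(C(=O)Nc5c(C)cccc5C)cc4s3)ncnc2cc1OCCCN1CCCCC1` carries piperidin-1-yl in that place, and in this assay compound 2 gives > 100000 nM, again only a limit. Compound 3 `COc1cc2c(Nc3nc4ccc(C(=O)Nc5c(C)cccc5C)cc4s3)ncnc2cc1OCCCN1CCC(C)CC1` carries 4-methylpiperidin-1-yl there; in this assay compound 3 gives > 100000 nM, also a limit. The steps a step that the two limits leave unreadable from compound 1 to compound 2, a step that the two limits leave unreadable from compound 1 to compound 3 and a step that the two limits leave unreadable from compound 2 to compound 3 cannot be sized, since (the limit of > 100000 nM in this assay, at which 3 of the 3 values shown sit). Compound 2 thus stands at the limit, with no number of its own to compare.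

Compound 4 `COc1cc2c(Nc3nc4ccc(C(=O)Nc5c(C)cc(C)cc5C)cc4s3)ncnc2cc1OCCCN1CCCCC1` differs from compound 2 by methyl in place of hydrogen on an aromatic carbon; cut one bond further out, the change reads 2,6-dimethylphenyl to 2,4,6-trimethylphenyl. None of the three measured steps gives a readable size that bears on this change. Compound 4 is therefore expected to sit near the same limit, with an estimated value of 150000 nM, between 50000 nM and 500000 nM. The step is expected to be a step that the limit leaves unreadable from compound 2 to compound 4.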

Compound 4, half-maximal inhibitory concentration: 16900 nM
For compound 4 the middle estimate is 8.9-fold (0.95 log units) above the measured one; measured number below the stated range.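

In this assay, putting methyl in place of hydrogen on the aromatic carbon para to a large group, which turns 2,6-dimethylphenyl into 2,4,6-trimethylphenyl, gives an at least 5.9-fold lower number from compound 2 to compound 4 (0.77 log units; beyond the scatter). This is the only step shown that can be sized: the earlier changes, all on the saturated ring of the side chain, could not be read, whereas this single added carbon at the other end of the molecule brings a measured number into view. Its full size stays unknown, since compound 2 has only a limit: the limit of > 100000 nM in this assay, at which 3 of the 4 values shown sit.

The compounds shown leave open whether methyl itself matters at this position, or whether a chlorine, a methoxy group or a carboxylic acid there would do the same. They also leave open whether 2,4,6-trimethylphenyl would lower the number with a pyrrolidin-1-yl or 4-methylpiperidin-1-yl side chain.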